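Phenethyl in Place of 4-Ethylphenyl on a Sulfur

This account rests on a few compounds, and the source may have more. Where it says the series, first, only, none or still open, it means among the compounds named here.

Three related compounds have so far been tested in a functional assay on SMMC-7721 cells (Homo sapiens) for inhibition, read by CCK-8 assay, with a stated time of 72 h, tested at 8 uM; on this read-out higher numbers stand for more inhibition of growth at the one concentration tested and lower numbers for less inhibition of growth. Compound 1 `CCc1ccc(SCc2ccc(/C=C/C(=O)Nc3ccccc3N)cc2)cc1` gives 19.5%, the middle of the three numbers. Compound 2 `CCc1ccc(SCc2ccc(C(=O)Nc3ccccc3N)cc2)cc1` gives 82.9%, much higher and well beyond the usual scatter of such measurements. Compound 3 `Nc1ccccc1NC(=O)c1ccc(CSc2ccc(C(F)(F)F)cn2)cc1` gives 7.57%, which also lies lower than the number for compound 1 by more than that scatter.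

Compound 4 `Nc1ccccc1NC(=O)/C=C/c1ccc(CSCCc2ccccc2)cc1` has not yet been measured. It holds the same atoms as compound 1, joined differently: phenethyl in place of 4-ethylphenyl on a sulfur. In words, phenethyl stands in place of 4-ethylphenyl on a sulfur, and the sulfur's other neighbour is a saturated chain carbon.

Going by the values given here, no two measured compounds show this change on its own, so the data give no direct guide to its size. The safest starting point is therefore compound 1 itself, at 19.5%. The expected step of a number 3.5 percentage points higher from compound 1 to compound 4 (within the scatter) is not beyond the scatter, and no firm direction can be expected. The wide spread of the three measured numbers still calls for a broad range. For compound 4 the estimated value in this assay is 23%, with an expected range from 5% to 50%.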

Compound 4, percent growth inhibition at one concentration: 15.8%
Estimate against measurement, compound 4: 7.2 percentage points above; measured number inside the range.
By their numbers in this assay, from the lowest: compounds 3, 4 and 1 (each within the scatter of the next, the first and the last beyond it); then compound 2.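

In this assay, going by these compounds alone, there is now a first pair of compounds that differ in one place, and it gives a number 3.7 percentage points lower from compound 1 to compound 4 (within the scatter) for phenethyl in place of 4-ethylphenyl on a sulfur. The two groups have the same count of 8 heavy atoms and each carries one six-membered aromatic ring of carbon only, but they are joined differently, and on this shared core the two numbers cannot be told apart. Within the data shown here, this single pair therefore gives a first direct reading at this position, which the earlier compounds could not give, but the data offer no measured explanation for it.

The pair leaves open whether other groups on the sulfur would fit the same picture, for example a longer chain such as 3-phenylpropyl, a benzyl group, or a phenethyl group carrying an amine or a carboxylic acid on its ring. It also leaves open what phenethyl would do on the core of compound 2, which holds 4-ethylphenyl on the sulfur and gives 82.9% in this assay.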